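The source may hold more compounds than are shown below. What is called first, only, known or untested is meant among the compounds shown, and "the series" means these compounds.

Measured compounds:
- compound 1, `C=C1C[C@]23C[C@@]1(O)CC[C@@H]2c1cccc(C)c1[C@@H]3Cn1cc(-c2ccccc2)nn1`: > 20000 nM
- compound 2, `C=C1C[C@]23C[C@@]1(O)CC[C@@H]2c1cccc(C)c1[C@@H]3Cn1cc(-c2ccc(C(F)(F)F)cc2)nn1`: > 20000 nM
- compound 3, `C=C1C[C@]23C[C@@]1(O)CC[C@H]2c1ccc(OS(=O)(=O)c2ccc(C)cc2)c(C)c1[C@@H]3Cn1cc(-c2ccccc2)nn1`: > 20000 nM

In a functional assay on A549 cells (Homo sapiens) for cytotoxicity, read by MTT assay, with a stated time of 4 days (on this read-out higher numbers stand for weaker inhibition and lower numbers for stronger inhibition), compound 1 gives > 20000 nM, which is a limit of the assay and not a number. In this assay compound 2 likewise gives > 20000 nM, again a limit. Compound 3 gives > 20000 nM in this assay, also a limit.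

Compound 2 differs from compound 1 by trifluoromethyl in place of hydrogen on an aromatic carbon. Going by these compounds, the step that the two limits leave unreadable from compound 1 to compound 2 cannot be read, because the limit of > 20000 nM in this assay, at which 3 of the 3 values shown sit: both ends sit at the same limit, so the size of the step stays unknown.

Compound 4, `C=C1C[C@]23C[C@@]1(O)CC[C@H]2c1ccc(OS(=O)(=O)c2ccc(C)cc2)c(C)c1[C@@H]3Cn1cc(-c2ccc(C(F)(F)F)cc2)nn1`, is not yet measured. The difference between the core of compound 3 and the core of compound 1 is not broken down here. Compound 4 differs from compound 3 by trifluoromethyl in place of hydrogen on an aromatic carbon. The place of this change reads word for word as the place of the change from compound 1 to compound 2, so it is the same change made on a different core.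

The expected step from compound 3 to compound 4 is a step that the limit leaves unreadable from compound 3 to compound 4 in this assay, and this expectation rests on compound 1 and compound 2 both sitting at the limit of > 20000 nM in this assay, at which 3 of the 3 values shown sit, with compound 3 sitting at the same limit. Compound 4 is therefore estimated to give 30000 nM in this assay, with the range 12000 nM to 100000 nM, and most likely the assay reports only a limit again.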

Compound 4, half-maximal inhibitory concentration: > 20000 nM
Compound 4: only a limit was reported; the forecaster's own chance of this, stated with the estimate: 85%; the middle value does not contradict the limit.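

In this assay compound 4 gives > 20000 nM, which is a limit and not a number. No new step can be read from compound 3 to compound 4, as both compounds sit at the same limit: the limit of > 20000 nM in this assay, at which 4 of the 4 values shown sit.

The compounds shown leave open how strongly any of them acts on these cells, and whether trifluoromethyl in place of hydrogen changes the read-out on either core.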